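The source may report more compounds than this note shows. Statements on the series, on what has been measured and on what is new or still open speak of the compounds shown alone.

Measured compounds:
compound 1 `COc1ccc(S(=O)(=O)c2ccccc2)c(Cc2c3c(n(CC(=O)O)c2C)CCNC3=O)c1` — 3.6 nM
compound 2 `Cc1c(Cc2ccccc2S(=O)(=O)c2ccccc2F)c2c(n1CC(=O)O)CCNC2=O` — 3.6 nM
compound 3 `COc1cccc(S(=O)(=O)c2ccccc2Cc2c3c(n(CC(=O)O)c2C)CCNC3=O)c1` — 12 nM

All three are read in a functional assay on CHO.K1 cells for antagonist activity at prostaglandin D2 receptor 2 (Homo sapiens), read by GTPgammaS binding, with a stated time of 1 h; a lower number here means a stronger inhibitor, a higher number a weaker inhibitor. Compound 3 gives the highest of the three numbers in this assay; compound 1 and compound 2 both sit at the same lower value, and each gap to compound 3 lies beyond the scatter. Going by the values given here, the only single-point step among the measured compounds is a 3.3-fold higher number from compound 2 to compound 3 (0.52 log units; beyond the scatter), a modest rise when a 3-methoxyphenyl replaces a 2-fluorophenyl on the sulfonyl sulfur.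

Compound 4 is `Cc1c(Cc2ccccc2S(=O)(=O)c2ccc(F)cc2)c2c(n1CC(=O)O)CCNC2=O`, not yet measured. It differs from compound 3 by 4-fluorophenyl in place of 3-methoxyphenyl on a sulfonyl sulfur. Among the compounds with values here, this is not the exact reverse of the measured step: the fluorophenyl that enters is a 4-fluorophenyl, whereas compound 2 carries a 2-fluorophenyl, and no measured pair tests that particular group. Within the data shown here, only the step from compound 2 to compound 3 bears on it, so a drop of roughly that size is expected, with wider uncertainty. In this assay the expected step is a 2.4-fold lower number from compound 3 to compound 4 (0.38 log units; beyond the scatter). Compound 4 is estimated at 5 nM, within 1.5 nM to 16 nM.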

Compound 4, half-maximal inhibitory concentration: 3.3 nM
Estimate against measurement, compound 4: 1.5-fold (0.18 log units) above; measured number inside the range.
By their numbers in this assay, from the lowest: compounds 4, 1 and 2 (each within the scatter of the next); then compound 3.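

In this assay the 3-methoxyphenyl group on the sulfonyl sulfur is now set against a second fluorophenyl, and the replacement by 4-fluorophenyl gives a modest gain (a 3.6-fold lower number from compound 3 to compound 4 (0.56 log units; beyond the scatter)). The two fluorophenyl groups cannot be told apart here (a 1.1-fold lower number from compound 2 to compound 4 (0.04 log units; within the scatter)), so moving from 2-fluorophenyl to 4-fluorophenyl leaves the number unchanged within the scatter, and compound 3 remains the only one of these sulfonyl variants with a higher number. Nothing available accounts for this difference.

As far as these compounds go, whether the higher number of compound 3 follows the methoxy group itself or the place it occupies remains open; a 4-methoxyphenyl or a 3-fluorophenyl on the sulfonyl sulfur would separate the two. From the compounds shown here alone, how an aminophenyl or a pyridyl group would read at this sulfur also remains open.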